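Swapping 2-chlorophenyl for 3-bromophenyl at an assay limit

A few compounds are considered here, and "the series" means these few. Any claim that something is new, unique, unknown or untested is made for them only; others in the source may bear on it.

In a functional assay on HUVEC cells (Homo sapiens) for antiproliferative activity, read by MTT assay, with a stated time of 24 h (on this read-out higher numbers stand for weaker inhibition and lower numbers for stronger inhibition), compound 2 `COc1cc(OC)c(-c2coc3cc(OCc4ccccc4Cl)ccc3c2=O)cc1OC` gives > 10000 nM, which is a limit of the assay and not a number. Compound 1 `COc1cc(OC)c(-c2coc3cc(OCc4ccc(F)cc4)ccc3c2=O)cc1OC` gives > 10000 nM, which is likewise a limit. Compound 3 `COc1cc(OC)c(-c2coc3cc(OCc4cccc(Br)c4)ccc3c2=O)cc1OC` keeps the shared core and carries 3-bromophenyl in place of 2-chlorophenyl on a saturated chain carbon bound to an oxygen on an aromatic ring. Within the data shown here, the only measured step at this place is a step that the two limits leave unreadable from compound 1 to compound 2. It offers no size to carry forward, and the whole evidence so far is the limit of > 10000 nM in this assay, at which 2 of the 2 values shown sit. No measured number therefore shows that a change of this group can move the read-out in this assay. The expectation rests on compound 2, which stands at > 10000 nM, a limit. No step beyond the usual scatter is expected, and no direction can be named. The estimated change is a step that the limit leaves unreadable from compound 2 to compound 3, and it is expected to stay within that scatter. The estimate for compound 3 is 12000 nM, with an expected range from 3000 nM to 30000 nM.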

Compound 3, half-maximal inhibitory concentration: > 10000 nM
Compound 3: no number, only a limit; the forecaster's own chance of this, stated with the estimate: 80%; the middle value is on the limit's open side.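

In this assay compound 3 gives > 10000 nM as a limit of the assay and not a number. Among these compounds, no step among compound 1, compound 2 and compound 3 can be read, and the evidence stands as follows: the limit of > 10000 nM in this assay, at which 3 of the 3 values shown sit. The compounds shown leave open whether any change of this group on the saturated chain carbon can move the read-out in this assay at all.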